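This account rests on a few compounds, and the source may have more. Where it says the series, first, only, none or still open, it means among the compounds named here.

Measured so far:
compound 1 `COc1cc(/C=C/C(=O)C2=C(/C=C/c3ccc(O)c(OC)c3)NC(=O)NC2c2ccc(C)cc2)ccc1O` — 52.2%
compound 2 `COc1cc(/C=C/C(=O)C2=C(/C=C/c3ccc(O)c(OC)c3)NC(=O)NC2c2ccc(O)cc2)ccc1O` — 86.2%

In a functional assay, with a stated time of 20 min, tested at 50 uM (on this read-out lower numbers stand for a weaker effect and higher numbers for a stronger effect at the one concentration tested), compound 2 stands highest of the two numbers; its nearest neighbour is compound 1, and the step of a number 34 percentage points higher from compound 1 to compound 2 (beyond the scatter) is the only one measured. Compound 3 `COc1cc(/C=C/C(=O)C2=C(/C=C/c3ccc(O)c(OC)c3)NC(=O)NC2c2ccc(N(C)C)cc2)ccc1O` is not yet measured. It differs from compound 2 by dimethylamino in place of hydroxy on an aromatic carbon. For the measured compounds named here, the one measured step touches the same position and was large, so this position matters in this assay, but no step from hydroxy to dimethylamino is known. The step from compound 2 to compound 3 is therefore expected to be a number 21.2 percentage points lower from compound 2 to compound 3 (beyond the scatter), most likely downward but wide. For compound 3 the estimate in this assay is 65%, between 40% and 90%.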

Compound 3, a percentage reported as activity, at one concentration (the size of the read-out at that concentration, not a potency): 89.2%
Compound 3: middle estimate off by 24.2 percentage points, on the low side; the range from low to high includes it.
By their numbers in this assay, from the lowest: compound 1; then compounds 2 and 3 (each within the scatter of the next).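

In this assay the swap of hydroxy for dimethylamino gives a number 3 percentage points higher from compound 2 to compound 3 (within the scatter) and so separates 4-(dimethylamino)phenyl from 4-hydroxyphenyl by no more than the scatter, even though dimethylamino has 0 hydrogen-bond donors. For the compounds shown here, with a number 37 percentage points higher from compound 1 to compound 3 (beyond the scatter) as the second step, methyl is the only one of the three groups that stands apart at this place. Nothing measured here gives a reason for these steps. From the compounds shown here alone, whether a primary amine, methoxy or chloro at this place would match hydroxy and dimethylamino or methyl stays open. A carboxylic acid is equally unresolved.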